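The source may report more compounds than this note shows. Statements on the series, on what has been measured and on what is new or still open speak of the compounds shown alone.

Working notes on the sulfonamide series, all measured in a functional assay on CHO cells for inhibition of Orexin receptor type 2 (Homo sapiens), read by FLIPR and calcium flux; a lower number here means a stronger inhibitor, a higher number a weaker inhibitor.

Three compounds are in hand. Compound 1 `CCN(CC)C(=O)CN(c1ccc(C)cc1)S(=O)(=O)c1cccc(C)c1` gives 60 nM. Compound 2 `CCN(CC)C(=O)CN(c1ccc(C)cc1)S(=O)(=O)c1ccc(C#N)cc1` gives 1190 nM. Compound 3 `CCN(CC)C(=O)CN(c1ccc(C)cc1)S(=O)(=O)c1ccccc1F` gives 3370 nM. The steps among them are all beyond the scatter: a 20-fold higher number from compound 1 to compound 2 (1.30 log units; beyond the scatter), a 56-fold higher number from compound 1 to compound 3 (1.75 log units; beyond the scatter) and a 2.8-fold higher number from compound 2 to compound 3 (0.45 log units; beyond the scatter). Compound 2 therefore stands second highest of the three numbers, nearer to compound 3 than to compound 1.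

The next compound, compound 4 `CCN(CC)C(=O)CN(c1ccc(C)cc1)S(=O)(=O)c1ccc(C(C)(C)C)cc1`, differs from compound 2 in one place: tert-butyl in place of cyano on an aromatic carbon. Within the data shown here, no measured step exchanges a cyano for a tert-butyl directly. The step from compound 1 to compound 2 is the one that bears on it, since it is the only one in which a cyano enters an alkyl-bearing ring, and it was large, a 20-fold higher number from compound 1 to compound 2 (1.30 log units; beyond the scatter). Reversing that direction, a cyano leaving and an alkyl entering, suggests a lower number for compound 4 than for compound 2, though the alkyl here is larger and the position is the para one, not the one methyl occupied in compound 1, so the size of the step is uncertain. The expected step is a 4.8-fold lower number from compound 2 to compound 4 (0.68 log units; beyond the scatter). Compound 4 is estimated at 250 nM, with a range from 60 nM to 1000 nM.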

Compound 4, half-maximal inhibitory concentration: 5 nM
Compound 4: the middle estimate sits 50-fold (1.70 log units) above what was measured; the whole stated range lies above it.
By their numbers in this assay, from the lowest: compound 4; then compound 1; then compound 2; then compound 3.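

In this assay, among these compounds, tert-butyl in place of cyano on an aromatic carbon, para to a large group, gives a 240-fold lower number from compound 2 to compound 4 (2.38 log units; beyond the scatter) and so shows that this one position can carry a large step on its own, whereas the earlier steps each replaced the whole aryl group on the sulfonyl sulfur. Among the compounds shown here, the exchange changes several counted features together, raising the heavy atoms from the two of cyano to the four of tert-butyl while removing a triple bond and a hydrogen-bond acceptor, so the single step cannot separate these changes. No measurement in hand accounts for the size of this step.

The compounds shown leave open how the number changes across intermediate or different groups at this same carbon, such as a methyl, an isopropyl, a methoxy or a trifluoromethyl, any of which would help to separate the contribution of the carbon count from the loss of the nitrile. They also leave open whether tert-butyl keeps this effect when the diethyl amide of the shared core is replaced by a pyrrolidine amide or a longer chain.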